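Changing the Benzyl Group of a Weak Inhibitor

This account rests on a few compounds, and the source may have more. Where it says the series, first, only, none or still open, it means among the compounds named here.

Measured so far in a functional assay on Z-138 cells (Homo sapiens) for antiproliferative activity, read by luminescence, with a stated time of 72 h; on this read-out higher numbers stand for weaker inhibition and lower numbers for stronger inhibition:
- compound 1 `Nc1ncnc2c1c(-c1ccc(Oc3ccccc3)cc1)nn2Cc1cccc(NC(=O)CCl)c1`: 800 nM
- compound 2 `Nc1ncnc2c1c(-c1ccc(Oc3ccccc3)cc1)nn2Cc1ccccc1F`: 43700 nM

Of these two, compound 2 has the higher number (43700 nM) and so the weaker inhibition. The next compound, compound 3 `Nc1cccc(Cn2nc(-c3ccc(Oc4ccccc4)cc3)c3c(N)ncnc32)c1`, differs from it at one place: 3-aminophenyl in place of 2-fluorophenyl on a saturated chain carbon bound to an aromatic nitrogen. In words, 3-aminophenyl sits in place of 2-fluorophenyl on a saturated chain carbon bound to an aromatic nitrogen. Going by the values given here, one measured step bears on this place, and it is large: a 55-fold higher number from compound 1 to compound 2 (1.74 log units; beyond the scatter). Compound 3 resembles compound 1 (800 nM) in its amino group but lacks the (chloromethyl)carbonyl part, so only some of that step is expected to return. In this assay the expected change is a 3.6-fold lower number from compound 2 to compound 3 (0.56 log units; beyond the scatter), a moderate move toward stronger inhibition. Compound 3 is estimated at 12000 nM with an expected range of 2500 nM to 45000 nM in this measurement.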

Compound 3, half-maximal inhibitory concentration: 14200 nM
The estimate for compound 3 lay 1.2-fold (0.07 log units) below the measured number, within the range that was stated.
By their numbers in this assay, from the lowest: compound 1; then compound 3; then compound 2.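

In this assay, 3-aminophenyl in place of 2-fluorophenyl on the saturated chain carbon gives a 3.1-fold lower number from compound 2 to compound 3 (0.49 log units; beyond the scatter), so this exchange on its own recovers only a modest part of the distance between the two earlier compounds. The larger difference goes with the (chloromethyl)carbonyl on the nitrogen: replacing it with hydrogen gives an 18-fold higher number from compound 1 to compound 3 (1.25 log units; beyond the scatter), which shows that an amino group alone does not match compound 1. Nothing measured here explains either step.

From the compounds shown here alone, whether a plain acetyl group on that nitrogen, lacking the chlorine, would stay close to compound 1 remains open. So does whether a hydroxyl group in place of the amino group would give a number like that of compound 3.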